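Cytotoxicity on the shared core: from compound 3 to compound 4

A few compounds are considered here, and "the series" means these few. Any claim that something is new, unique, unknown or untested is made for them only; others in the source may bear on it.

Three compounds of the series have been run in an ADME assay on PC-3 cells (Homo sapiens) for cytotoxicity, read by WST assay, tested at 100 uM; on this read-out lower numbers stand for less inhibition and higher numbers for more inhibition at the one concentration tested (going by the name of the read-out). Compound 1 `Cc1nc(-c2cccc(NC(=O)C3CCCN(C(=O)c4cc(C(F)(F)F)cc(C(F)(F)F)c4)C3)c2)cs1` gives 1%, compound 2 `O=C(Nc1cccc([N+](=O)[O-])c1)C1CCCN(C(=O)c2cc(C(F)(F)F)cc(C(F)(F)F)c2)C1` gives 9%, and compound 3 `O=C(Nc1cccc(Cc2ccccc2)c1)C1CCCN(C(=O)c2cc(C(F)(F)F)cc(C(F)(F)F)c2)C1` gives 0%. All three numbers lie within the scatter of one another: from compound 1 to compound 3 the step is a number 1 percentage points lower from compound 1 to compound 3 (within the scatter), and from compound 2 to compound 3 it is a number 9 percentage points lower from compound 2 to compound 3 (within the scatter). Compound 3 thus sits with compound 1 as its nearest neighbour and compound 2 as its furthest, neither gap being beyond the scatter.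

Compound 4 `Cn1cnnc1-c1cccc(NC(=O)C2CCCN(C(=O)c3cc(C(F)(F)F)cc(C(F)(F)F)c3)C2)c1` has not yet been measured. It differs from compound 3 by 4-methyl-4H-1,2,4-triazol-3-yl in place of benzyl on an aromatic carbon. Among the measured compounds shown here, the step that bears on this change is the one from compound 1 to compound 3, which exchanges one heteroaromatic ring for benzyl at the same position and gave a number 1 percentage points lower from compound 1 to compound 3 (within the scatter); the step from compound 2 to compound 3, a number 9 percentage points lower from compound 2 to compound 3 (within the scatter), also ends at benzyl and is likewise within the scatter. No replacement at this position has so far moved the read-out beyond the scatter, so for compound 4 no step beyond the scatter is expected in this assay , the expected step being a number 2 percentage points higher from compound 3 to compound 4 (within the scatter). Compound 4 is estimated at 2%, with a range from -6% to 10%.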

Compound 4, a percentage reported as inhibition, at one concentration (the size of the read-out at that concentration, not a potency): 0%
Compound 4: middle estimate off by 2 percentage points, on the high side; measured number inside the range.
By their numbers in this assay, from the lowest: compounds 3, 4, 1 and 2 (each within the scatter of the next).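

In this assay, the place on an aromatic carbon meta to a large group now also carries 4-methyl-4H-1,2,4-triazol-3-yl, a group with hydrogen-bond acceptors and ring nitrogen that benzyl lacks, and the exchange gives no change at the digits printed from compound 3 to compound 4 (within the scatter). The result widens the set of groups at this place without moving the read-out beyond the scatter: against nitro the step is a number 9 percentage points lower from compound 2 to compound 4 (within the scatter), and against 2-methyl-1,3-thiazol-4-yl it is a number 1 percentage points lower from compound 1 to compound 4 (within the scatter), so none of the four groups shown goes against this flat picture. Nothing available explains why the read-out stays flat across these exchanges.

The compounds shown leave open whether an aminomethyl group or a carboxylic acid at this place, which would add a kind of group absent from the four compounds, would give a step beyond the scatter in this assay. They also leave open what happens when the change is made elsewhere on the shared core, for example with a methoxy group in place of either trifluoromethyl group.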